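This account rests on a few compounds, and the source may have more. Where it says the series, first, only, none or still open, it means among the compounds named here.

The measured compounds:
- compound 1, `O=C(NC1CC1)c1[nH]cnc1-c1nc2ccccc2[nH]1`, gives 35200 nM in a functional assay on MDA-MB-231 cells (Homo sapiens) for inhibition, read by MTT assay, with a stated time of 48 h; a higher number here means a weaker inhibitor, a lower number a stronger inhibitor
- compound 2, `O=C(NCC1CC1)c1[nH]cnc1-c1nc2ccccc2[nH]1`, gives 33100 nM in this assay
- compound 3, `O=C(NC1CCCCCC1)c1[nH]cnc1-c1nc2ccccc2[nH]1`, reaches only a limit of the assay, > 40000 nM, in this assay

Compound 2 holds the lowest of the two numbers in this assay; the nearest is compound 1, and the step of a 1.1-fold lower number from compound 1 to compound 2 (0.03 log units; within the scatter) stays within the usual scatter. Compound 3 sits at the limit (the limit of > 40000 nM in this assay, at which 1 of the 3 values shown sits), so its step from compound 2, an at least 1.2-fold higher number from compound 2 to compound 3 (0.08 log units; that floor lies within the scatter), has only a floor, and that floor also lies within the scatter.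

Compound 4, `O=C(NCc1ccco1)c1[nH]cnc1-c1nc2ccccc2[nH]1`, is the next change on the same amide-type nitrogen: furan-2-yl in place of cyclopropyl on a saturated chain carbon bound to an amide-type nitrogen. The steps seen so far all alter the group on that nitrogen, from cyclopropyl to cyclopropylmethyl and to cycloheptyl, and none of them moved the number beyond the scatter. A ring that is aromatic and carries one hetero atom is new here, so the expectation rests on a thin base. The step of a 1.1-fold lower number from compound 2 to compound 4 (0.04 log units; within the scatter) is expected to be small. Compound 4 is estimated at 30000 nM, with a range from 12000 nM to 70000 nM.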

Compound 4, half-maximal inhibitory concentration: 22200 nM
Compound 4: middle estimate off by 1.4-fold (0.13 log units), on the high side; measured number inside the range.
By their numbers in this assay, from the lowest: compounds 4, 2 and 1 (each within the scatter of the next). At a limit, above all of these: compound 3.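

Furan-2-yl in place of cyclopropyl puts an aromatic ring with a hetero atom and a hydrogen-bond acceptor on this chain for the first time, yet the number stays close to those of the non-aromatic groups: the two steps, a 1.5-fold lower number from compound 2 to compound 4 (0.17 log units; within the scatter) and a 1.6-fold lower number from compound 1 to compound 4 (0.20 log units; within the scatter), both stay within the scatter. Compound 3 gives a limit rather than a number: the limit of > 40000 nM in this assay, at which 1 of the 4 values shown sits. The comparison with compound 3 therefore offers only a floor, an at least 1.8-fold lower number from compound 3 to compound 4 (0.25 log units; that floor lies within the scatter), so even this larger difference in the group on the nitrogen shows no clear change.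

From the compounds shown here alone, it remains open whether an amine or a carboxylic acid on this chain would move the number beyond the scatter. Also open, going by these compounds, is whether a change to the shared core, rather than to this group, would do so.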